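A 2-chlorophenyl swap at the assay limit

The source may hold more compounds than are shown below. What is called first, only, known or untested is meant among the compounds shown, and "the series" means these compounds.

In a functional assay on HepG2 cells (Homo sapiens) for antiproliferative activity, read by MTT assay, with a stated time of 24 h (on this read-out lower numbers stand for stronger inhibition and higher numbers for weaker inhibition), compound 1 (`COc1ccc(C(=O)/C=C/c2cccc(F)c2)c2c1C=CC(C)(C)O2`) gives > 10000 nM as a limit and not a number. Compound 2 (`COc1ccc(C(=O)/C=C/c2ccccc2)c2c1C=CC(C)(C)O2`) gives > 10000 nM as a limit too. Compound 3 (`COc1ccc(C(=O)/C=C/c2ccco2)c2c1C=CC(C)(C)O2`) also stands only at a limit of > 10000 nM in this read-out. Compound 4 (`COc1ccc(C(=O)/C=C/c2ccccc2Cl)c2c1C=CC(C)(C)O2`) has 2-chlorophenyl in place of furan-2-yl on a double-bonded chain carbon bound to a double-bonded chain carbon. The closest evidence is a step that the two limits leave unreadable from compound 2 to compound 3 together with a step that the two limits leave unreadable from compound 1 to compound 2 and a step that the two limits leave unreadable from compound 1 to compound 3 and all three rest on the limit of > 10000 nM in this assay, at which 3 of the 3 values shown sit, alone. No direction is therefore expected in this assay and the estimated change is a step that the limit leaves unreadable from compound 3 to compound 4 in size. Compound 4 is estimated at 15000 nM with an expected range from 5000 nM to 50000 nM and may well return only a limit.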

Compound 4, half-maximal inhibitory concentration: > 10000 nM
Compound 4 gave a limit, no number; the forecaster's own chance of this, stated with the estimate: 75%; the middle value is on the limit's open side.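

Compound 4 gives > 10000 nM, which is a limit, so no step linking it to compound 1, compound 2 or compound 3 can be read in this assay: the limit of > 10000 nM in this assay, at which 4 of the 4 values shown sit.

The compounds shown leave open whether these four groups differ at all in this assay.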